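Furan-2-yl replaced by 3,4,5-trimethoxyphenyl

This account rests on a few compounds, and the source may have more. Where it says the series, first, only, none or still open, it means among the compounds named here.

Values in a functional assay on THP-1 cells (Homo sapiens) for inhibition, read by sulforhodamine B assay, with a stated time of 48 h, tested at 50 uM; on this read-out higher numbers stand for more inhibition of growth at the one concentration tested and lower numbers for less inhibition of growth:
Compound 1 `COc1ccc(/C=C/C(=O)/C=C/c2ccc(OCc3cn(CCCCOc4cc(=O)oc5ccccc45)nn3)c(OC)c2)cc1OC`: 59%
Compound 2 `COc1cc(/C=C/C(=O)/C=C/c2ccco2)ccc1OCc1cn(CCCCOc2cc(=O)oc3ccccc23)nn1`: 49%

Within the data shown here, compound 2, at 49%, stands within the scatter of its only measured neighbour, the step being a number 10 percentage points lower from compound 1 to compound 2 (within the scatter). Compound 3 `COc1cc(/C=C/C(=O)/C=C/c2cc(OC)c(OC)c(OC)c2)ccc1OCc1cn(CCCCOc2cc(=O)oc3ccccc23)nn1` differs from it by 3,4,5-trimethoxyphenyl in place of furan-2-yl on a double-bonded chain carbon bound to a double-bonded chain carbon. Among the measured compounds shown here, only that one step bears on this change, as it exchanged 3,4-dimethoxyphenyl for furan-2-yl at the same place. Since it stayed within the scatter, no step beyond the scatter is expected here. The expected step is a number 6 percentage points higher from compound 2 to compound 3 (within the scatter). For compound 3 the estimated value is 55%, with an expected range of 42% to 70%.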

Compound 3, percent growth inhibition at one concentration: 65%
Compound 3: the middle estimate sits 10 percentage points below what was measured, and the stated range covers the measured number.
By their numbers in this assay, from the lowest: compounds 2, 1 and 3 (each within the scatter of the next, the first and the last beyond it).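

In this assay, among these compounds, 3,4,5-trimethoxyphenyl in place of furan-2-yl gives the first step at this double-bonded chain carbon that lies beyond the scatter (a number 16 percentage points higher from compound 2 to compound 3 (beyond the scatter)), whereas the step between 3,4-dimethoxyphenyl and furan-2-yl stayed within it. Methoxy in place of hydrogen on an aromatic carbon stays within the scatter (a number 6 percentage points higher from compound 1 to compound 3 (within the scatter)), so compound 1 and compound 3 cannot be separated. No measured evidence explains these steps.

As far as these compounds go, whether an unsubstituted phenyl ring or a phenyl ring carrying a dimethylamino group or a carboxylic acid would match compound 3 remains open.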